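Compound 1 to compound 3: exchanging the pyridinyl group

The source may hold more compounds than are shown below. What is called first, only, known or untested is meant among the compounds shown, and "the series" means these compounds.

In a functional assay on K562 cells (Homo sapiens) for inhibition, read by MTT assay, with a stated time of 48 h (a higher number here means a weaker inhibitor, a lower number a stronger inhibitor), compound 1 (`CC(=O)Nc1ccc(-c2ccc(C(=O)N[C@H]3CN[C@@H](C(=O)Nc4ccc(Cl)c(C(F)(F)F)c4)C3)cc2)cn1`) gives 22800 nM and compound 2 (`CCN(CC)C(=O)c1cncc(-c2ccc(C(=O)N[C@@H](C)C(=O)Nc3ccc(Cl)c(C(F)(F)F)c3)cc2)c1`) gives 20200 nM. Among the measured compounds shown here, these two numbers lie within the scatter of each other, so compound 1 stands level with the only other measured compound.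

Compound 3 (`O=C(NC1CC1)c1cncc(-c2ccc(C(=O)N[C@H]3CN[C@@H](C(=O)Nc4ccc(Cl)c(C(F)(F)F)c4)C3)cc2)c1`) keeps the core of compound 1 and carries 5-(cyclopropylcarbamoyl)pyridin-3-yl in place of 6-acetamidopyridin-3-yl on an aromatic carbon. For the measured compounds named here, no measured pair isolates a change of this kind. The expectation therefore rests on compound 1 at 22800 nM, and no step beyond the scatter is expected in this assay, with no direction favoured. The expected size of the change is a 1.3-fold lower number from compound 1 to compound 3 (0.10 log units; within the scatter). The estimated value for compound 3 is 18000 nM, with an expected range of 7000 nM to 45000 nM.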

Compound 3, half-maximal inhibitory concentration: 65300 nM
Estimate against measurement, compound 3: 3.6-fold (0.56 log units) below; the whole stated range lies below it.
By their numbers in this assay, from the lowest: compounds 2 and 1 (each within the scatter of the next); then compound 3.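

In this assay, 5-(cyclopropylcarbamoyl)pyridin-3-yl in place of 6-acetamidopyridin-3-yl gives a 2.9-fold higher number from compound 1 to compound 3 (0.46 log units; beyond the scatter), the only step in the series shown that lies beyond the scatter. This aromatic carbon, para to a large group, is therefore not indifferent to the group it carries: on the shared core, this exchange weakens inhibition, even though both groups count the same hydrogen-bond donors and acceptors. Nothing available explains the step.

The exchange alters the substituent and its place on the pyridine ring together, so the compounds shown cannot separate the cyclopropyl group from the shift in attachment. Also open, from the compounds shown here alone, is how 6-(cyclopropylcarbamoyl)pyridin-3-yl, 5-acetamidopyridin-3-yl or a pyridine ring bearing a carboxylic acid would read here.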